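The compounds below may be only part of what the source reports. "The series", "measured", "known", "first", "only" and "open" are said of these compounds alone.

Measured in a functional assay on 786-0 cells (Homo sapiens) for inhibition, read by sulforhodamine B assay, with a stated time of 48 h; on this read-out higher numbers stand for weaker inhibition of growth and lower numbers for stronger inhibition of growth:
- Compound 1 `CC1(/C=C/c2ccccc2)C=CC(=O)O1`: 170000 nM
- Compound 2 `CC1(/C=C/c2ccc(C(F)(F)F)cc2)C=CC(=O)O1`: 34000 nM
- Compound 3 `COc1ccc(/C=C/C2(C)C=CC(=O)O2)c(OC)c1`: 108000 nM

Compound 2 has the lowest number of the three, and the next step leads from it to compound 4 `CC1(/C=C/c2ccc(O)cc2)C=CC(=O)O1`. That step is hydroxy in place of trifluoromethyl on an aromatic carbon. Among the compounds with values here, one measured step bears on it, the modest 5.0-fold lower number from compound 1 to compound 2 (0.70 log units; beyond the scatter), which came with trifluoromethyl in place of hydrogen. Within the data shown here, compound 4 loses that trifluoromethyl, but no measured compound carries hydroxy, so the reversal is expected to be only partial. A higher number, meaning weaker inhibition of growth, is therefore expected in this assay. The expected change is a 2.6-fold higher number from compound 2 to compound 4 (0.42 log units; beyond the scatter). Compound 4 is estimated at 90000 nM, with an expected range of 30000 nM to 250000 nM.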

Compound 4, concentration for total growth inhibition: 143000 nM
Estimate against measurement, compound 4: 1.6-fold (0.20 log units) below, within the range that was stated.
By their numbers in this assay, from the lowest: compound 2; then compounds 3, 4 and 1 (each within the scatter of the next).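

In this assay, hydroxy in place of trifluoromethyl on this aromatic carbon undoes the earlier step (a 4.2-fold higher number from compound 2 to compound 4 (0.62 log units; beyond the scatter)), while hydroxy in place of hydrogen leaves the number within the scatter (a 1.2-fold lower number from compound 1 to compound 4 (0.08 log units; within the scatter)). Among compounds 1, 2 and 4, therefore, only trifluoromethyl separates itself at this carbon, and hydroxy does not. Nothing available accounts for this difference. The compounds shown leave open how an amine, a carboxylic acid or a chlorine atom at this carbon would compare with trifluoromethyl.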